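A few compounds are considered here, and "the series" means these few. Any claim that something is new, unique, unknown or untested is made for them only; others in the source may bear on it.

Measured compounds in an ADME assay on MT4 cells (Homo sapiens) for cytotoxicity, read by MTT assay, with a stated time of 5 days; on this read-out lower numbers stand for higher toxicity in this test and higher numbers for lower toxicity in this test:

Compound 1, `COC(=O)c1ccc(NC(=O)COc2nc3ccccc3n2S(=O)(=O)c2cc(C)cc(C)c2)c(Cl)c1`, gives 119000 nM.
Compound 2, `Cc1cc(C)cc(S(=O)(=O)n2c(OCC(=O)Nc3ccc(S(N)(=O)=O)cc3Cl)nc3ccccc32)c1`, gives > 227000 nM, which is a limit of the assay and not a number.
Compound 3, `COC(=O)c1ccc(NC(=O)CSc2nc3ccccc3n2S(=O)(=O)c2cc(C)cc(C)c2)c(Cl)c1`, gives 145000 nM.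

Compound 3 stands at the highest number of the two measured as numbers in this assay, with compound 1 nearest and within the scatter of it. The difference between the core of compound 1 and the core of compound 3 is not broken down here.

The step from compound 1 to compound 2 is sulfamoyl in place of methoxycarbonyl on an aromatic carbon and moves the read-out by an at least 1.9-fold higher number from compound 1 to compound 2 (0.28 log units; that floor lies within the scatter); its floor rests on the limit (the limit of > 227000 nM in this assay, at which 1 of the 3 values shown sits).

Compound 4, `Cc1cc(C)cc(S(=O)(=O)n2c(SCC(=O)Nc3ccc(S(N)(=O)=O)cc3Cl)nc3ccccc32)c1`, is not yet measured in this assay. It differs from compound 3 by sulfamoyl in place of methoxycarbonyl on an aromatic carbon, the same change as that from compound 1 to compound 2, at the same place. Compound 4 is therefore expected to move by about a 1.8-fold higher number from compound 3 to compound 4 (0.25 log units; within the scatter), resting on the step of an at least 1.9-fold higher number from compound 1 to compound 2 (0.28 log units; that floor lies within the scatter) and the value of compound 3, 145000 nM. For compound 4 the estimate in this assay is 260000 nM, between 120000 nM and 550000 nM, with a fair chance that only a limit is reported.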

Compound 4, half-maximal cytotoxic concentration: 25600 nM
Compound 4: middle estimate off by 10-fold (1.01 log units), on the high side, outside the stated range (below it).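

In this assay, sulfamoyl in place of methoxycarbonyl on an aromatic carbon gives a 5.7-fold lower number from compound 3 to compound 4 (0.75 log units; beyond the scatter), so the result on one core does not carry over to the other in this pair of examples: the same change on two cores in this assay, an at least 1.9-fold higher number (0.28 log units; that floor lies within the scatter) from compound 1 to compound 2 and a 5.7-fold lower number (0.75 log units; beyond the scatter) from compound 3 to compound 4, at least 10-fold (1.03 log units) apart, beyond the scatter of two such steps Compound 2 is reported only as a limit of the assay and not as a number, so the earlier step gives a floor and not a size: the limit of > 227000 nM in this assay, at which 1 of the 4 values shown sits. The two pairs show that the outcome of this change depends on the core here, but they do not show which feature of the cores accounts for this, and they set no rule for any further core.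

The compounds shown leave open whether the lower number of compound 4 belongs to the sulfamoyl group alone or to its combination with that core. A carboxylic acid or a methylsulfonyl group at the same place on both cores would test whether the split between the cores extends beyond the sulfamoyl group.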